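A few compounds are considered here, and "the series" means these few. Any claim that something is new, unique, unknown or untested is made for them only; others in the source may bear on it.

Compound 1 `O=C(/C=C/[C@H]1C[C@@H](O)[C@@H](O)C1)Nc1ccccc1`: in an ADME assay on S2 cells (Drosophila melanogaster) for cytotoxicity, read by MTT assay (on this read-out lower numbers stand for an effect already at smaller amounts and higher numbers for an effect only at larger amounts of compound), compound 1 reaches only the limit of the test, > 200000 nM.
Compound 2 `O=C(/C=C/[C@H]1C[C@@H](O)[C@@H](O)C1)Nc1ccc(F)cc1`: in this assay compound 2 reaches only a limit, > 180000 nM.
Compound 3 `Cc1ccc(NC(=O)/C=C/[C@H]2C[C@@H](O)[C@@H](O)C2)cc1`: in this assay compound 3 reaches only a limit, > 190000 nM.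

The three compounds share one core and differ only in a small group on the aromatic ring. None of them produced a cytotoxic effect within the concentrations the test covers, so all three values are limits rather than numbers. Compound 3 therefore stands at a limit, and the two further values shown are limits too (the limit of > 190000 nM in this assay, at which 1 of the 3 values shown sits).

Compound 4 `COc1ccc(NC(=O)/C=C/[C@H]2C[C@@H](O)[C@@H](O)C2)cc1` differs from compound 3 by methoxy in place of methyl on an aromatic carbon. The steps measured so far, a step that the two limits leave unreadable from compound 1 to compound 2, a step that the two limits leave unreadable from compound 1 to compound 3 and a step that the two limits leave unreadable from compound 2 to compound 3, are all unreadable, since every compound sits at a limit (the limit of > 180000 nM in this assay, at which 1 of the 3 values shown sits, (the limit of > 200000 nM in this assay, at which 1 of the 3 values shown sits)). With nothing readable to build on, the step that the limit leaves unreadable from compound 3 to compound 4 is expected to be none beyond the scatter. Compound 4 is estimated to give about 200000 nM, within 100000 nM to 400000 nM, most likely again reported only as a limit.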

Compound 4, half-maximal effective concentration: > 180000 nM
Compound 4: no number, only a limit; the forecaster's own chance of this, stated with the estimate: 85%; the middle value is on the limit's open side.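

Compound 4 gives only a limit in this assay, as do compound 1, compound 2 and compound 3, so its steps to these three compounds cannot be read. The compounds shown leave open at what concentration any of them becomes cytotoxic, and whether the small group on the aromatic ring makes any difference.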